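From cyano to methoxy: an estimate for compound 3

The source may hold more compounds than are shown below. What is called first, only, known or untested is meant among the compounds shown, and "the series" means these compounds.

Compound 1 `CNC(=O)c1cc(Oc2ccc(C3=NNC(c4ccc(C#N)cc4)C3)cc2)ccn1`: 15000 nM
Compound 2 `CNC(=O)c1cc(Oc2ccc(C3=NNC(c4ccc([N+](=O)[O-])cc4)C3)cc2)ccn1`: > 50000 nM (a limit of the assay)

Among the measured compounds shown here, in a functional assay on HepG2 cells (Homo sapiens) for cytotoxicity, read by MTT assay, with a stated time of 72 h (on this read-out lower numbers stand for stronger inhibition and higher numbers for weaker inhibition), compound 1, at 15000 nM, holds the only true number so far. Compound 2 gives > 50000 nM, and this value is a limit of the assay, not a number.

The next compound to be measured is compound 3 `CNC(=O)c1cc(Oc2ccc(C3=NNC(c4ccc(OC)cc4)C3)cc2)ccn1`. It differs from compound 1 at a single place (methoxy in place of cyano on an aromatic carbon), with methoxy in place of cyano on an aromatic carbon, para to a large group.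

For the measured compounds named here, only one measured step bears on this change, the replacement of cyano by nitro on the same aromatic carbon, and it is an at least 3.3-fold higher number from compound 1 to compound 2 (0.52 log units; beyond the scatter). From the compounds shown here alone, its full size stays open, and it concerns a different incoming group, so it gives only a weak guide to direction. A small move towards weaker inhibition in this assay is therefore expected, possibly no larger than the scatter, and compound 3 could also reach the limit of the assay. The estimate amounts to an expected 1.6-fold higher number from compound 1 to compound 3 (0.20 log units; within the scatter). For compound 3 the expected value is 24000 nM, within an estimated range of 9000 nM to 50000 nM.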

Compound 3, half-maximal inhibitory concentration: 9640 nM
Estimate against measurement, compound 3: 2.5-fold (0.40 log units) above; low and high end bracket the measured number.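

In this assay, methoxy in place of cyano on this aromatic carbon gives a 1.6-fold lower number from compound 1 to compound 3 (0.19 log units; within the scatter), so the two groups cannot be told apart on this read-out. Methoxy in place of nitro at the same place gives an at least 5.1-fold lower number from compound 2 to compound 3 (0.71 log units; beyond the scatter), which shows that the weak result of compound 2 does not extend to every replacement of cyano at this position. The value of compound 2 is a limit and not a number, so the full size of that step stays open: the limit of > 50000 nM in this assay, at which 1 of the 3 values shown sits.

With only cyano, nitro and methoxy shown at this place, it remains open whether an amine, a hydroxyl group, a halogen such as chlorine or a longer chain such as ethoxy would side with compound 1 and compound 3 or with compound 2. The compounds shown also leave open what sets nitro apart from the other two groups, since three compounds at one position cannot settle that.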